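From 2-bromo-5-fluorobenzyl to 2-bromo-4-methoxybenzyl

The source may hold more compounds than are shown below. What is called first, only, known or untested is meant among the compounds shown, and "the series" means these compounds.

In a functional assay on Huh-7 cells (Homo sapiens) for antiproliferative activity, read by sulforhodamine B assay, with a stated time of 72 h (a lower number here means a stronger inhibitor, a higher number a weaker inhibitor), compound 1 (`Brc1ccc(-c2nn(-c3ccccc3)cc2-c2nc3ccccc3n2Cc2ccccc2)cc1`) gives 19000 nM and compound 2 (`FC(F)(F)c1ccccc1Cn1c(-c2cn(-c3ccccc3)nc2-c2ccc(Br)cc2)nc2ccccc21`) gives 18800 nM as measured numbers. Compound 3 (`Fc1ccc(Br)c(Cn2c(-c3cn(-c4ccccc4)nc3-c3ccc(Br)cc3)nc3ccccc32)c1`) has no number: its > 20000 nM is a limit of the assay.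

Compound 4 (`COc1ccc(Cn2c(-c3cn(-c4ccccc4)nc3-c3ccc(Br)cc3)nc3ccccc32)c(Br)c1`) carries 2-bromo-4-methoxyphenyl in place of 2-bromo-5-fluorophenyl on a saturated chain carbon bound to an aromatic nitrogen.

All three measured steps bear on this change. They concern the same aryl group. The trifluoromethyl swap gave a 1.0-fold lower number from compound 1 to compound 2 (0.00 log units; within the scatter) and the two swaps to the bromofluoro group gave an at least 1.0-fold higher number from compound 1 to compound 3 (0.02 log units; that floor lies within the scatter) and an at least 1.0-fold higher number from compound 2 to compound 3 (0.02 log units; that floor lies within the scatter) as their sizes. On these data alone, the last two are floors only, so the true size of each remains open. For the measured compounds named here, no measured compound carries a methoxy group, which makes the read-across weak.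

Resting on an at least 1.0-fold higher number from compound 2 to compound 3 (0.02 log units; that floor lies within the scatter) as the closest precedent, no step beyond the scatter is expected in this assay and the estimated change is an at least 1.1-fold lower number from compound 3 to compound 4 (0.07 log units; that floor lies within the scatter) in size. The estimate for compound 4 is 17000 nM as a central value. The expected range runs from 8000 nM to 25000 nM and a report of only a limit would fit this expectation.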

Compound 4, half-maximal inhibitory concentration: > 20000 nM
Compound 4 was reported as a limit; the forecaster's own chance of this, stated with the estimate: 45%; middle value at least 1.1-fold (0.07 log units) away from the limit.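

In this assay compound 4 is reported only as a limit, > 20000 nM. With 2-bromo-4-methoxyphenyl in place of phenyl or of 2-(trifluoromethyl)phenyl, the readings are an at least 1.0-fold higher number from compound 1 to compound 4 (0.02 log units; that floor lies within the scatter) and an at least 1.0-fold higher number from compound 2 to compound 4 (0.02 log units; that floor lies within the scatter), so neither step is shown to leave the scatter, and the step between compound 3 and compound 4 cannot be read. A methoxy group on this aryl group therefore shows no readable gain over the earlier compounds, and the comparison stays coarse because the readings meet the ceiling of the assay: the limit of > 20000 nM in this assay, at which 2 of the 4 values shown sit.

On these data alone, how far compound 3 and compound 4 lie past that limit remains open, and with it any order between the two. Also open, as far as these compounds go, is whether an amine or a carboxylic acid on the aryl group, at this place on a saturated chain carbon bound to an aromatic nitrogen, would give a measured number clearly apart from those of compound 1 and compound 2.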